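A few compounds are considered here, and "the series" means these few. Any claim that something is new, unique, unknown or untested is made for them only; others in the source may bear on it.

Measured in a functional assay on Caco-2 cells (Homo sapiens) for antiproliferative activity, read by MTT assay; a lower number here means a stronger inhibitor, a higher number a weaker inhibitor:
- compound 1 `NS(=O)(=O)c1ccc(/N=C2\NC(=O)/C(=C3/C(=O)Nc4ccc([N+](=O)[O-])cc43)S2)cc1`: 13800 nM
- compound 2 `Cc1ccc2c(c1)/C(=C1/S/C(=N/c3ccc(S(N)(=O)=O)cc3)NC1=O)C(=O)N2`: 174000 nM
- compound 3 `NS(=O)(=O)c1ccc(/N=C2\NC(=O)/C(=C3/C(=O)N(Cc4ccccc4)c4ccccc43)S2)cc1`: > 200000 nM, a limit and not a number

Compound 3 stands at the limit of > 200000 nM in this assay, at which 1 of the 3 values shown sits, so it has a limit and no exact value. Compound 4 `NS(=O)(=O)c1ccc(/N=C2\NC(=O)/C(=C3/C(=O)Nc4ccccc43)S2)cc1` differs from it in one place: hydrogen in place of benzyl on an amide-type nitrogen in a ring, with hydrogen in place of benzyl on an amide-type nitrogen in a ring.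

Among the compounds with values here, no measured step changes that nitrogen. Within the data shown here, the only measured step, a 13-fold higher number from compound 1 to compound 2 (1.10 log units; beyond the scatter), is large, but it puts methyl in place of nitro on an aromatic carbon, so it shows only how far a single change can move this assay. Compound 4 would share the amide hydrogen of the two compounds with exact values: compound 1 gives 13800 nM and compound 2 gives 174000 nM. A lower number is therefore expected, with the estimated step being an at least 2.8-fold lower number from compound 3 to compound 4 (0.45 log units; beyond the scatter), though its size is uncertain. For compound 4 the estimated value is 70000 nM, with an expected range of 20000 nM to 200000 nM.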

Compound 4, half-maximal inhibitory concentration: > 200000 nM
Compound 4 was reported as a limit (the forecaster's own chance of this, stated with the estimate: 20%); at least 2.8-fold (0.45 log units) between middle value and limit.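

In this assay, hydrogen in place of benzyl on the amide-type nitrogen leaves compound 4 at a limit as well, so the amide hydrogen alone gives no measurable value here: the limit of > 200000 nM in this assay, at which 2 of the 4 values shown sit. With both compounds at limits, the step between compound 3 and compound 4 cannot be read. Compound 4 does give the first reference with hydrogen on the aromatic carbon: hydrogen in place of nitro gives an at least 14-fold higher number from compound 1 to compound 4 (1.16 log units; beyond the scatter), which is large, while hydrogen in place of methyl gives an at least 1.1-fold higher number from compound 2 to compound 4 (0.06 log units; that floor lies within the scatter), whose floor lies within the scatter.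

The compounds shown leave open whether an amine or a chlorine on that aromatic carbon would also give a lower number than hydrogen. They also leave open what benzyl on the amide-type nitrogen would do in compound 1, which has an exact value.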